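The compounds below may be only part of what the source reports. "The series", "measured", "known", "first", "only" and "open" are said of these compounds alone.

The measured compounds are compound 1 `c1ccc(C(c2ccccc2)n2ccnn2)cc1`, compound 2 `CCCCCCc1cn(C(c2ccccc2)c2ccccc2)nn1` and compound 3 `CCCCCCCCCCc1cn(C(c2ccccc2)c2ccccc2)nn1`. In an assay on isolated protein for inhibition of Aromatase (Homo sapiens), read by fluorescence and colorimetric assay, with a stated time of 30 min (on this read-out lower numbers stand for stronger inhibition and higher numbers for weaker inhibition), compound 1 gives 4580 nM, compound 2 gives 14800 nM and compound 3 gives 13500 nM.

Compound 3 thus stands second highest among the three numbers; it sits close to compound 2, and its gap to compound 1 lies beyond the scatter. Compound 4 `Clc1ccc(OCc2cn(C(c3ccccc3)c3ccccc3)nn2)cc1` arises from compound 3 through (4-chlorophenoxy in place of nonyl on a saturated chain carbon bound to an aromatic carbon). Within the data shown here, two measured steps touch this position. The step of a 3.2-fold higher number from compound 1 to compound 2 (0.51 log units; beyond the scatter) placed a hexyl chain on the aromatic carbon and raised the number; the step of a 1.1-fold lower number from compound 2 to compound 3 (0.04 log units; within the scatter) lengthened that chain and changed nothing beyond the scatter. Among the measured compounds shown here, neither step exchanges a chain for an aryloxy group, so no measured step bears directly on the change in hand. What the two steps do show is that a substituent of roughly this size at this place has so far left the number in the region of compound 2 and compound 3 rather than back at compound 1. The number for compound 4 in this assay is therefore expected to stay near that of compound 3, with a step of a 1.4-fold lower number from compound 3 to compound 4 (0.13 log units; within the scatter), nothing beyond the scatter. Compound 4 is estimated at 10000 nM, with a range from 4000 nM to 25000 nM.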

Compound 4, half-maximal inhibitory concentration: 13400 nM
For compound 4 the middle estimate is 1.3-fold (0.13 log units) below the measured one; measured number inside the range.
By their numbers in this assay, from the lowest: compound 1; then compounds 4, 3 and 2 (each within the scatter of the next).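

The exchange of nonyl for 4-chlorophenoxy on a saturated chain carbon bound to an aromatic carbon gives, in this assay, a 1.0-fold lower number from compound 3 to compound 4 (0.00 log units; within the scatter), and the exchange of pentyl for the same group gives a 1.1-fold lower number from compound 2 to compound 4 (0.04 log units; within the scatter). At this place the read-out therefore does not separate a plain chain from a group that carries a six-membered aromatic ring of carbon only and a hydrogen-bond acceptor, something the chain compounds alone could not show. The (4-chlorophenoxy)methyl group in place of hydrogen on the aromatic carbon gives a 2.9-fold higher number from compound 1 to compound 4 (0.47 log units; beyond the scatter), so this group stands apart from compound 1 just as the chains do, and nothing measured here accounts for that.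

As far as these compounds go, what stays open is which part of the 4-chlorophenoxy group, if any, counts at this place, as the oxygen, the chlorine and the ring all enter together in compound 4. Also open, from the compounds shown here alone, is whether a group of another kind on that carbon, such as an amine or a carboxylic acid, would bring the number back toward that of compound 1 or leave it where compounds 2, 3 and 4 stand.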